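Shortening the Ether Side Chain Back Toward Compactness

The source may report more compounds than this note shows. Statements on the series, on what has been measured and on what is new or still open speak of the compounds shown alone.

Compound 1 `CC(C)Oc1cccc2ccc(N)nc12`: 437 nM
Compound 2 `CC(C)OCCOc1cccc2ccc(N)nc12`: > 2000 nM

Of the compounds shown here, two have been measured in an assay on cells with melanin-concentrating hormone receptor 1 (Homo sapiens) as the target, read by radioligand binding; on this read-out higher numbers stand for weaker inhibition and lower numbers for stronger inhibition. Compound 1 carries an isopropyl on an oxygen on an aromatic ring and gives 437 nM. Compound 2 gives only a limit of the assay rather than a number, namely > 2000 nM. The step of an at least 4.5-fold higher number from compound 1 to compound 2 (0.66 log units; beyond the scatter) is therefore a lower bound; its true size is open, as the limit of > 2000 nM in this assay, at which 1 of the 2 values shown sits, is where compound 2 sits. On the numbers shown, compound 2 is the weaker of the two, with its inhibitory concentration lying beyond the point the assay can resolve.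

Compound 3 `Nc1ccc2cccc(OCC3CC3)c2n1` is not yet measured. It differs from compound 2 by cyclopropyl in place of isopropoxymethyl on a saturated chain carbon bound to an oxygen on an aromatic ring. Within the data shown here, only the step from compound 1 to compound 2 bears on this change, and it went upward when the side chain grew longer. Returning to a compact group resembles compound 1 more than compound 2, so a downward step an at least 5.0-fold lower number from compound 2 to compound 3 (0.69 log units; beyond the scatter) is expected for compound 3. The estimate for compound 3 is 400 nM, with a range from 100 nM to 2000 nM.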

Compound 3, half-maximal inhibitory concentration: > 2000 nM
Compound 3 was reported as a limit (the forecaster's own chance of this, stated with the estimate: 20%); middle value at least 5.0-fold (0.69 log units) away from the limit.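

In this assay, cyclopropylmethyl in place of isopropyl on an oxygen on an aromatic ring gives an at least 4.5-fold higher number from compound 1 to compound 3 (0.66 log units; beyond the scatter), so the loss seen with the long 2-isopropoxyethyl chain is not confined to that chain: a second group on the same oxygen, one with no further oxygen and with a three-membered ring, also fails to keep the measured number of compound 1. Among these compounds, compound 3 gives only a limit of the assay, > 2000 nM, which leaves isopropyl as the only group on this oxygen with an actual number so far. The step between compound 2 and compound 3 cannot be read because both compounds sit at the same limit: the limit of > 2000 nM in this assay, at which 2 of the 3 values shown sit.

Going by these compounds, how far compound 2 and compound 3 each lie past that limit remains open, and so does any difference between isopropoxymethyl and cyclopropyl at this place. Also open, on these data alone, is whether a methyl, an ethyl or a tert-butyl group on this oxygen would give a number near that of compound 1, or a lower one.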